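Ester-substituted thiazolone series: aryl to pyrrolyl swap on the exocyclic carbon

The compounds below may be only part of what the source reports. "The series", "measured", "known", "first", "only" and "open" are said of these compounds alone.

Measured so far:
- compound 1 `CCOC(=O)C1=C(Nc2ccccc2)S/C(=C\c2ccc(OC)cc2)C1=O`: 17.5%
- compound 2 `CCOC(=O)C1=C(Nc2cccc(C(F)(F)F)c2)S/C(=C\c2ccc[nH]2)C1=O`: 22.8%

In a functional assay on A549 cells (Homo sapiens) for inhibition, read by MTT assay, with a stated time of 72 h, tested at 10 uM (on this read-out lower numbers stand for less inhibition and higher numbers for more inhibition at the one concentration tested (going by the name of the read-out)), compound 1 gives 17.5%, the lower of the two numbers at hand. Compound 2 gives 22.8% in this assay, a number within the scatter of that of compound 1, so the two show the same size of effect; compound 2 also differs from compound 1 at two places, so no single step can be read from the pair.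

Compound 3 `CCOC(=O)C1=C(Nc2ccccc2)S/C(=C\c2cc[nH]c2)C1=O` is not yet measured. It differs from compound 1 by one change: 1H-pyrrol-3-yl in place of 4-methoxyphenyl on a double-bonded chain carbon bound to a double-bonded ring carbon. Among the compounds with values here, no step between measured compounds isolates this change, so the expectation rests on the flat picture from compound 1 and compound 2. The step from compound 1 to compound 3 is expected to be a number 2.5 percentage points higher from compound 1 to compound 3 (within the scatter), not beyond the scatter. Compound 3 is estimated at 20% in this assay, in the range 8% to 32%.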

Compound 3, a percentage reported as inhibition, at one concentration (the size of the read-out at that concentration, not a potency): < 10%
Compound 3 was reported as a limit; the forecaster's own chance of this, stated with the estimate: 5%; middle value at least 10 percentage points away from the limit.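

Within the data shown here, this is the first step that isolates a single place, the double-bonded chain carbon bound to a double-bonded ring carbon, which the two-place pair of compound 1 and compound 2 could not do. Putting 1H-pyrrol-3-yl in place of 4-methoxyphenyl there gives a number at least 7.5 percentage points lower from compound 1 to compound 3 (that floor lies within the scatter), so the data do not yet show this place to be sensitive to the change. In this assay, compound 3 gives < 10%, which is a limit of the assay and not a number, so the full size of the step stays unknown: the limit of < 10% in this assay, at which 1 of the 3 values shown sits.

The other steps among these compounds cannot be read, as each pair differs in more than one place. Still open, from the compounds shown here alone, is how a carboxylic acid or a dimethylamino group on the phenyl ring at this place would read out.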